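From Aziridine to Methoxypropylamine: One Substitution, One Estimate

The source may hold more compounds than are shown below. What is called first, only, known or untested is meant among the compounds shown, and "the series" means these compounds.

Measured so far:
compound 1 `O=C1C=C(N2CC2)C(=O)c2nc(-c3ccccc3)ccc21`: 3310 nM
compound 2 `Cc1ccc2c(n1)C(=O)C=C(N1CC1)C2=O`: 2040 nM
compound 3 `C=CCNC1=CC(=O)c2nc(-c3ccccc3)ccc2C1=O`: 14100 nM

The three compounds share a core and have been tested in a functional assay on NCI60 cells (Homo sapiens) for cytotoxicity; a higher number here means a weaker inhibitor of growth, a lower number a stronger inhibitor of growth. Compound 1 gives the second highest of the three numbers. Its nearest neighbour is compound 2, whose number is lower but within the scatter, so the two cannot be told apart. The furthest is compound 3, whose number is higher by more than the scatter, so compound 3 is the weaker growth inhibitor of that pair.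

Compound 4 `COCCCNC1=CC(=O)c2ccc(-c3ccccc3)nc2C1=O` has not yet been measured in this assay. It differs from compound 1 in one place: (3-methoxypropyl)amino in place of aziridin-1-yl on a double-bonded ring carbon. The entering group brings 1 hydrogen-bond donor where the aziridine had none.

Among the compounds with values here, no single-place step between measured compounds exists to lean on. Still, compound 3, which also carries an open-chain amino group, gives 14100 nM, a weaker result than compound 1. Compound 4 is therefore expected to be a weaker growth inhibitor than compound 1, with a step estimated at a 3.6-fold higher number from compound 1 to compound 4 (0.56 log units; beyond the scatter), beyond the scatter. Compound 4 is estimated at 12000 nM, within a range from 4000 nM to 35000 nM.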

Compound 4, concentration for total growth inhibition: 28800 nM
Compound 4: the middle estimate sits 2.4-fold (0.38 log units) below what was measured; the range from low to high includes it.
By their numbers in this assay, from the lowest: compounds 2 and 1 (each within the scatter of the next); then compound 3; then compound 4.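

With the rest of the structure held fixed, the group on this double-bonded ring carbon clearly matters in this assay: putting (3-methoxypropyl)amino in place of aziridin-1-yl gives an 8.7-fold higher number from compound 1 to compound 4 (0.94 log units; beyond the scatter). This single change removes a three-membered ring, lengthens the substituent and adds a hydrogen-bond donor all at once, and one step cannot separate these differences. Nothing shown here explains why the number rises.

As far as these compounds go, it remains open whether the ring itself or the amine hydrogen matters more. A dimethylamino group would have an open chain without that hydrogen, while an azetidine ring would keep a small ring without it; a methylamino group would show whether a much shorter chain behaves like the (3-methoxypropyl)amino group.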